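This account rests on a few compounds, and the source may have more. Where it says the series, first, only, none or still open, it means among the compounds named here.

Compound 1 `COc1cc(-c2cc(/C=C/C(=O)c3ccc(N)cc3)[nH]n2)cc(OC)c1OC`: 2050 nM
Compound 2 `COc1ccc(C(=O)/C=C/c2cc(-c3cc(OC)c(OC)c(OC)c3)n[nH]2)cc1`: 1860 nM

Of the compounds shown here, two have been measured in a functional assay on Malme-3M cells (Homo sapiens) for inhibition, read by sulforhodamine B assay, with a stated time of 48 h; on this read-out higher numbers stand for weaker inhibition of growth and lower numbers for stronger inhibition of growth. Compound 1 gives 2050 nM and compound 2 gives 1860 nM. Among the compounds with values here, compound 2 stands at the lower of these two numbers, but the only measured step, a 1.1-fold lower number from compound 1 to compound 2 (0.04 log units; within the scatter), lies within the scatter, so the two compounds cannot be told apart on this read-out.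

Compound 3 `COc1cc(-c2cc(/C=C/C(=O)c3ccc(F)c(F)c3)[nH]n2)cc(OC)c1OC` is not yet measured. It differs from compound 2 in one place: 3,4-difluorophenyl in place of 4-methoxyphenyl on a carbonyl carbon. Within the data shown here, the single measured step bears on the same ring, where a methoxy and an amino gave numbers within the scatter of each other. Nothing measured shows what a 3,4-difluorophenyl does here. The expectation is therefore a step of a 1.1-fold higher number from compound 2 to compound 3 (0.03 log units; within the scatter) from compound 2 to compound 3, with no change beyond the scatter foreseen. On that basis compound 3 is estimated at 2000 nM, with a range from 600 nM to 7000 nM.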

Compound 3, concentration for 50% growth inhibition: 2960 nM
For compound 3 the middle estimate is 1.5-fold (0.17 log units) below the measured one; measured number inside the range.
By their numbers in this assay, from the lowest: compounds 2, 1 and 3 (each within the scatter of the next).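

In this assay, within the data shown here, a 1.6-fold higher number from compound 2 to compound 3 (0.20 log units; within the scatter) and a 1.4-fold higher number from compound 1 to compound 3 (0.16 log units; within the scatter) both leave compound 3 indistinguishable from the earlier compounds. The aromatic ring on the carbonyl carbon has now carried amino, methoxy and two fluorines, and among these three compounds, 3,4-difluorophenyl is as acceptable as 4-methoxyphenyl or 4-aminophenyl. No supporting measurement is available to say what lies behind these small differences.

On these data alone, it remains open whether any group at this position can move the number beyond the scatter, such as a carboxylic acid on the ring or a cyclohexyl in place of the aromatic ring. Also open, as far as these compounds go, is whether a change elsewhere on the shared core, such as a longer chain, would matter more than this one.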